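The compounds below may be only part of what the source reports. "The series", "measured", "known", "first", "only" and "open" are said of these compounds alone.

In a physicochemical assay for solubility, at pH 7.4 (a lower number here means a less soluble compound, a higher number a more soluble compound), compound 1 `Cc1cc(NC(=O)Nc2ccc(F)cc2)c2ccccc2n1` gives 3700 nM and compound 2 `Cc1cc(NC(=O)Nc2ccc(F)cc2F)c2ccccc2n1` gives 3000 nM. Among the compounds with values here, these two values lie within the scatter of each other, so compound 1 cannot be separated from its only measured neighbour. The next compound is compound 3 `Cc1cc(NC(=O)Nc2ncccc2C)c2ccccc2n1`, with 3-methylpyridin-2-yl in place of 4-fluorophenyl on an amide-type nitrogen. Within the data shown here, the only measured step, a 1.2-fold lower number from compound 1 to compound 2 (0.09 log units; within the scatter), is fluoro in place of hydrogen on an aromatic carbon and lies within the scatter. Among the measured compounds shown here, no measured step exchanges the whole group, so that step says little about this change, and the data give no direction for it. No step beyond the scatter is expected in this assay, though with low confidence. The expected step is a 1.1-fold higher number from compound 1 to compound 3 (0.03 log units; within the scatter). For compound 3 the estimated value is 4000 nM, with an expected range of 1300 nM to 12000 nM.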

Compound 3, solubility: 1300 nM
Estimate against measurement, compound 3: 3.1-fold (0.49 log units) above, and the stated range covers the measured number.
By their numbers in this assay, from the lowest: compound 3; then compounds 2 and 1 (each within the scatter of the next).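

In this assay, within the data shown here, the exchange on the amide-type nitrogen is the first change to move beyond the scatter: a 2.8-fold lower number from compound 1 to compound 3 (0.45 log units; beyond the scatter). This position therefore responds to replacing the whole 4-fluorophenyl with 3-methylpyridin-2-yl, which the fluoro exchange, a 1.2-fold lower number from compound 1 to compound 2 (0.09 log units; within the scatter), did not show, and the number falls even though the entering group has a hydrogen-bond acceptor that the leaving group lacks. No measurement at hand accounts for this step.

On these data alone, the exchange alters the ring atom and adds the methyl at once, so the share of each in the step remains open. A pyridin-2-yl without the methyl, set against compound 3 , would separate the two.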